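Methyl in place of hydrogen on compound 3

The source may hold more compounds than are shown below. What is called first, only, known or untested is meant among the compounds shown, and "the series" means these compounds.

Three compounds have been run in a functional assay on KB cells (Homo sapiens) for antiproliferative activity, read by sulforhodamine B assay, with a stated time of 72 h; a lower number here means a stronger inhibitor of growth, a higher number a weaker inhibitor of growth. Compound 1 `Cc1cc(=O)oc2cc(Sc3cccc(Cl)[n+]3[O-])ccc12` returns only a limit, > 31200 nM. Compound 2 `Cc1cc(=O)oc2cc(SC3CCOC3=O)ccc12` likewise returns only a limit, > 36100 nM. Compound 3 `CCc1cc(=O)c2ccc(Sc3cccc(Cl)[n+]3[O-])cc2o1` also sits at a limit, > 29900 nM. With every reading a limit (the limit of > 29900 nM in this assay, at which 1 of the 3 values shown sits, (the limit of > 31200 nM in this assay, at which 1 of the 3 values shown sits), (the limit of > 36100 nM in this assay, at which 1 of the 3 values shown sits)), no number places compound 3 above or below the others; it simply stands among limits.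

Compound 4 `CCc1cc(=O)c2ccc(Sc3cccc(Cl)[n+]3[O-])c(C)c2o1` differs from compound 3 by methyl in place of hydrogen on an aromatic carbon. Within the data shown here, no measured step of this kind exists in the set, so no change beyond the scatter is expected, and another limit is the most likely outcome. The expected step from compound 3 to compound 4 is a step that the limit leaves unreadable from compound 3 to compound 4. For compound 4 the estimate in this assay is 40000 nM, ranging from 15000 nM to 100000 nM.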

Compound 4, concentration for 50% growth inhibition: > 28700 nM
Compound 4 gave a limit, no number; the forecaster's own chance of this, stated with the estimate: 80%; the middle value is on the limit's open side.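

Compound 3 and compound 4 both stand at limits, so the step for methyl in place of hydrogen on an aromatic carbon cannot be read. The compounds shown leave open how strongly, if at all, any of them inhibits growth.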